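Pyrrolidine sulfonamide series: moving the chloro substituent

This account rests on a few compounds, and the source may have more. Where it says the series, first, only, none or still open, it means among the compounds named here.

Compound 1 `O=C(c1ccc(OCCCN2CC[C@H](NS(=O)(=O)c3cccc(Cl)c3)C2)cc1)C1CC1` gives 700 nM in an assay on isolated protein for binding affinity to histamine H2 receptor (Homo sapiens) (on this read-out lower numbers stand for stronger inhibition and higher numbers for weaker inhibition), the lowest of the three numbers at hand. Compound 3 `CC(=O)c1ccc(OCCCN2CC[C@H](NS(=O)(=O)c3ccc(C#N)cc3)C2)cc1` gives 2300 nM and compound 2 `CC(=O)c1ccc(OCCCN2CC[C@H](NC(=O)c3csc(-c4cccnc4)n3)C2)cc1` gives 6200 nM; both gaps to compound 1 lie beyond the scatter, so compound 1 stands as the strongest binder of the three measured.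

Compound 4 `O=C(c1ccc(OCCCN2CC[C@H](NS(=O)(=O)c3ccc(Cl)cc3)C2)cc1)C1CC1` has not been measured. It differs from compound 1 by 4-chlorophenyl in place of 3-chlorophenyl on a sulfonyl sulfur. For the measured compounds named here, no measured pair isolates this change, and compound 3 carries a different group on the aryl ketone as well, so it does not serve as a direct guide. A step from compound 1 to compound 4 of about a 1.4-fold higher number from compound 1 to compound 4 (0.15 log units; within the scatter) is expected, probably toward weaker binding but likely within the scatter. Compound 4 is estimated at 1000 nM, with a range from 350 nM to 3000 nM.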

Compound 4, inhibition constant: 290 nM
The estimate for compound 4 lay 3.4-fold (0.54 log units) above the measured number; measured number below the stated range.
By their numbers in this assay, from the lowest: compound 4; then compound 1; then compound 3; then compound 2.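

Going from 3-chlorophenyl to 4-chlorophenyl on a sulfonyl sulfur gives a 2.4-fold lower number from compound 1 to compound 4 (0.38 log units; beyond the scatter) in this assay, so binding at this position depends on where the chlorine stands, even with the same atoms present. For the compounds shown here, this modest step, beyond the scatter, is the first reading of a change made in one place. No measured evidence bears on what lies behind it.

Open, going by these compounds, is whether a bromine or a methoxy group in place of the chlorine would give a similar number. Also open, on these data alone, is whether the step carries over with another group on the aryl ketone.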